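Compound 3 to compound 4: trifluoromethyl for 2-fluoropyridin-3-yl

A few compounds are considered here, and "the series" means these few. Any claim that something is new, unique, unknown or untested is made for them only; others in the source may bear on it.

Three measured compounds share one core and differ in a single aromatic group: compound 1 `O=C(Nc1ccc(F)c(-c2nc3ncc(-c4ccc(F)cc4F)cc3[nH]2)c1)N1CCCC1`, compound 2 `O=C(Nc1ccc(F)c(-c2nc3ncc(-c4ccc(F)cc4)cc3[nH]2)c1)N1CCCC1` and compound 3 `O=C(Nc1ccc(F)c(-c2nc3ncc(-c4cccnc4F)cc3[nH]2)c1)N1CCCC1`. In an ADME assay on the whole organism (Mus musculus, strain Swiss Webster) for pharmacokinetics, read by LC-MS, at a dose of 50 mg/kg by the oral route (on this read-out higher numbers stand for higher exposure at the dose given and lower numbers for lower exposure), compound 1 gives 9500 nM, compound 2 gives 6270 nM and compound 3 gives 25600 nM, the highest of the three numbers.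

Compound 4 `O=C(Nc1ccc(F)c(-c2nc3ncc(C(F)(F)F)cc3[nH]2)c1)N1CCCC1` carries trifluoromethyl in place of 2-fluoropyridin-3-yl on an aromatic carbon. The measured steps all change this same place, but each one swaps one aromatic ring for another. The change among the two phenyl compounds stays within the scatter, as a 1.5-fold lower number from compound 1 to compound 2 (0.18 log units; within the scatter) shows. Reaching compound 3 takes modest steps, a 2.7-fold higher number from compound 1 to compound 3 (0.43 log units; beyond the scatter) and a 4.1-fold higher number from compound 2 to compound 3 (0.61 log units; beyond the scatter). Among the measured compounds shown here, no measured compound has lost the ring, so the data give no direct measure of this change.

Compound 3 stands above compound 1 and compound 2, so a fall in this assay is the likelier direction, towards the level of compound 1 at 9500 nM, though with little certainty. The expected step is a 2.8-fold lower number from compound 3 to compound 4 (0.45 log units; beyond the scatter). Compound 4 is estimated at 9000 nM, with an expected range of 2500 nM to 30000 nM.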

Compound 4, maximal plasma concentration: 1080 nM
Beside the measured number, compound 4's estimate is 8.3-fold (0.92 log units) above it, and the stated range ends above it.
By their numbers in this assay, from the lowest: compound 4; then compounds 2 and 1 (each within the scatter of the next); then compound 3.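

In this assay, among the compounds shown here, the first compound without an aromatic ring at this position falls below all three ring-bearing compounds, with a 24-fold lower number from compound 3 to compound 4 (1.37 log units; beyond the scatter) and a 5.8-fold lower number from compound 2 to compound 4 (0.76 log units; beyond the scatter) and an 8.8-fold lower number from compound 1 to compound 4 (0.94 log units; beyond the scatter) as the steps. The earlier steps shown here only exchanged one aromatic ring for another, while these show that trifluoromethyl on this aromatic carbon gives a lower number than any of the three rings tested, making compound 4 the lowest of the four. The step from the 2-fluoropyridin-3-yl compound is the only one of the three classed as large, so the choice of group at this position can move maximal plasma concentration substantially at this oral dose.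

The compounds shown leave open whether the aromatic ring itself is what matters or whether another group at this carbon, such as a saturated morpholine ring or a butyl chain, would reach the level of the ring-bearing compounds. No available measurement accounts for the fall from any ring-bearing compound to compound 4.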